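A second hydroxy group on an already inactive scaffold

The source may hold more compounds than are shown below. What is called first, only, known or untested is meant among the compounds shown, and "the series" means these compounds.

Compound 1 `CCn1cnc2ncnc(N)c21` and compound 2 `Nc1ncnc2ncn(CCO)c12` share a core and differ by hydroxy in place of hydrogen on a saturated chain carbon, two bonds along the chain from an aromatic nitrogen. In an assay on CHO cells for displacement of a labelled ligand from adenosine receptor A3 (Homo sapiens) (on this read-out higher numbers stand for weaker inhibition and lower numbers for stronger inhibition), compound 1 gives only a limit, > 100000 nM. In this assay compound 2 likewise gives only a limit, > 100000 nM. The step that the two limits leave unreadable from compound 1 to compound 2 therefore cannot be read. Compound 3 `CC(O)Cn1c(Br)nc2c(N)ncnc21` carries a different core; the difference between the two cores is not broken down here. In this assay compound 3 also gives a limit, >= 100000 nM. Compound 4 `Nc1ncnc2c1nc(Br)n2CC(O)CO` differs from compound 3 by hydroxy in place of hydrogen on a saturated chain carbon, two bonds along the chain from an oxygen on a saturated carbon, the same kind of change as before, though here the place lies two bonds along the chain from an oxygen on a saturated carbon rather than from an aromatic nitrogen. Because every value sits at the limit of > 100000 nM in this assay, at which 2 of the 3 values shown sit, or (the limit of >= 100000 nM in this assay, at which 1 of the 3 values shown sits), no step size is known, and the expected step of a number no higher from compound 3 to compound 4 (the limit leaves the size open) is accordingly small. Compound 4 is expected to give about 100000 nM, most probably again only a limit.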

Compound 4, inhibition constant: >= 100000 nM
Compound 4: a limit, no number (the forecaster's own chance of this, stated with the estimate: 85%); the middle value sits exactly at the limit.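

Compound 3 and compound 4 each give only a limit, not a number, so the step between them cannot be read. The compounds shown leave open how strongly any of them truly binds, and whether adding a hydroxy changes that.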